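Bromo in Place of Hydrogen on the Core of Compound 1

A few compounds are considered here, and "the series" means these few. Any claim that something is new, unique, unknown or untested is made for them only; others in the source may bear on it.

Among the measured compounds shown here, compound 1 `COc1cc(/C(Cl)=C/C=C(\C#N)C(=O)c2c[nH]c3ccccc23)cc(OC)c1OC` is one of three compounds measured in a functional assay for inhibition, with a stated time of 30 min, tested at 1 mM; on this read-out higher numbers stand for more inhibition at the one concentration tested (going by the name of the read-out) and lower numbers for less inhibition. In this assay compound 1 gives 21.1%, the second highest of the three numbers. Compound 3 `COc1ccc(/C(Cl)=C/C=C(\C#N)C(=O)c2c[nH]c3ccc(Br)cc23)cc1` gives 15.6%, a number lower than that of compound 1 by a difference within the usual scatter, so the two cannot be told apart. Compound 2 `COc1ccc2[nH]cc(C(=O)/C(C#N)=C/C=C(\Cl)c3ccc(OC)c(OC)c3)c2c1` gives 34.2%, a number higher than that of compound 1 by a difference beyond the scatter.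

Compound 4 `COc1cc(/C(Cl)=C/C=C(\C#N)C(=O)c2c[nH]c3ccc(Br)cc23)cc(OC)c1OC` differs from compound 1 in one place: bromo in place of hydrogen on an aromatic carbon. For the measured compounds named here, no pair of measured compounds shows this difference alone, so no measured step tells what to expect of it. Compound 3 also carries a bromo group on its core, and the read-out hardly moves, because compound 3 gives 15.6% while compound 1 gives 21.1%. The step is therefore expected to be a number 0.9 percentage points higher from compound 1 to compound 4 (within the scatter), no change beyond the scatter. Compound 4 is expected to give about 22%, within a range from 10% to 34%.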

Compound 4, a percentage reported as inhibition, at one concentration (the size of the read-out at that concentration, not a potency): 26.3%
The estimate for compound 4 lay 4.3 percentage points below the measured number, and the stated range covers the measured number.
By their numbers in this assay, from the lowest: compounds 3, 1, 4 and 2 (each within the scatter of the next, the first and the last beyond it).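

Among the compounds shown here, with the change from 1H-indol-3-yl to 5-bromo-1H-indol-3-yl, this assay gives a direct reading of this position for the first time: a number 5.2 percentage points higher from compound 1 to compound 4 (within the scatter). For the compounds shown here, on the core of compound 1, bromo in place of hydrogen on this aromatic carbon therefore brings no change that can be told from the scatter, which the earlier compounds could not show, since compound 3 differs from compound 1 in more than one place. No measurement shown here speaks to the reason for this outcome.

On these data alone, how an amine, a carboxylic acid or a longer chain would read at this position remains open. Also open, as far as these compounds go, is whether bromo in place of hydrogen would give a similar step on a compound with a different substitution pattern on its other aromatic ring.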